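The source may hold more compounds than are shown below. What is called first, only, known or untested is meant among the compounds shown, and "the series" means these compounds.

In a functional assay on IMR-32 cells (Homo sapiens) for cytotoxicity, read by sulforhodamine B assay, with a stated time of 48 h (a lower number here means a stronger inhibitor, a higher number a weaker inhibitor), compound 1 `COc1cc(C2CC(c3ccccc3)=NN2C(C)=O)ccc1O` gives 5780 nM, compound 2 `CC(=O)N1N=C(c2ccco2)CC1c1ccc([N+](=O)[O-])cc1` gives 35800 nM, and compound 3 `CC(=O)N1N=C(c2ccco2)CC1c1ccc(Br)cc1` gives 47800 nM. Compound 3 stands at the highest of these three numbers, though its gap to compound 2 lies within the scatter, while the gap to compound 1 lies beyond it. Compound 4 `CC(=O)N1N=C(c2ccco2)CC1c1ccc(Cl)cc1` differs from compound 3 in one place: chloro in place of bromo on an aromatic carbon. Within the data shown here, only one measured step bears on a change of this kind, the one a 1.3-fold higher number from compound 2 to compound 3 (0.13 log units; within the scatter), which swapped one substituent for another on the same aromatic carbon and moved the number by an amount within the scatter. On that basis a halogen-for-halogen exchange at this position is expected to move the number little, with no step beyond the scatter in either direction in this assay. For compound 4 the number in this assay is therefore estimated at 45000 nM, between 20000 nM and 100000 nM, a step of a 1.1-fold lower number from compound 3 to compound 4 (0.03 log units; within the scatter) that is expected to stay within the scatter.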

Compound 4, half-maximal inhibitory concentration: 38900 nM
The estimate for compound 4 lay 1.2-fold (0.06 log units) above the measured number; the range from low to high includes it.
By their numbers in this assay, from the lowest: compound 1; then compounds 2, 4 and 3 (each within the scatter of the next).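

In this assay, chloro in place of bromo on the aromatic carbon para to a large group gives a 1.2-fold lower number from compound 3 to compound 4 (0.09 log units; within the scatter), so a direct exchange of one halogen for another now stands beside the earlier nitro-to-bromo step, and it too lies within the scatter. The step of a 1.1-fold higher number from compound 2 to compound 4 (0.04 log units; within the scatter) adds a second exchange at this place that stays within the scatter, so compound 2, compound 3 and compound 4 cannot be told apart by their numbers here. Nothing measured on these compounds accounts for this result.

On these data alone, whether an amine, a carboxylic acid or a longer chain on this carbon would move the number beyond the scatter remains open. So does the effect of a change elsewhere on the shared core.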